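Adding a second chloro to the urea aryl ring

A few compounds are considered here, and "the series" means these few. Any claim that something is new, unique, unknown or untested is made for them only; others in the source may bear on it.

Of the compounds shown here, three of a shared core have been measured in a functional assay on MKN-45 cells (Homo sapiens) for cytotoxicity, read by MTT assay, with a stated time of 72 h; a higher number here means a weaker inhibitor, a lower number a stronger inhibitor. Compound 1 `CN(C)CCCNc1nc(-c2ccc(NC(=O)Nc3ccc(Cl)cc3Cl)cc2)nc2ccsc12` gives 2270 nM. Compound 2 `CCN(CC)CCNc1nc(-c2ccc(NC(=O)Nc3ccccc3F)cc2)nc2ccsc12` gives 1040 nM, and compound 3 `CCN(CC)CCNc1nc(-c2ccc(NC(=O)Nc3ccccc3Cl)cc2)nc2ccsc12` gives 750 nM. Compound 3 has the lowest of the three numbers; its nearest neighbour is compound 2, and the step of a 1.4-fold lower number from compound 2 to compound 3 (0.14 log units; within the scatter) lies within the scatter, so the two cannot be ranked. Compound 1 is further off, beyond the scatter, but it differs from compound 3 in two places, so no single change can be read from that gap.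

Compound 4 `CCN(CC)CCNc1nc(-c2ccc(NC(=O)Nc3ccc(Cl)cc3Cl)cc2)nc2ccsc12` differs from compound 3 by chloro in place of hydrogen on an aromatic carbon. Among the compounds with values here, no measured pair isolates this change: the only single-point step, from compound 2 to compound 3, swaps one halogen for another and stays within the scatter. With nothing showing that a halogen on this ring moves the number far, the step of a 1.2-fold higher number from compound 3 to compound 4 (0.08 log units; within the scatter) in this assay is expected to stay within the scatter, with the higher number of compound 1 leaving some room for a weaker result. Compound 4 is therefore estimated at 900 nM, with a range from 350 nM to 2500 nM.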

Compound 4, half-maximal inhibitory concentration: 1520 nM
For compound 4 the middle estimate is 1.7-fold (0.23 log units) below the measured one, and the stated range covers the measured number.
By their numbers in this assay, from the lowest: compounds 3, 2, 4 and 1 (each within the scatter of the next, the first and the last beyond it).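

In this assay, within the data shown here, the step of a 2.0-fold higher number from compound 3 to compound 4 (0.31 log units; beyond the scatter) is the first single change in this set to reach beyond the scatter, though only modestly: chloro in place of hydrogen, para to a large group on the urea aryl ring, goes with a higher number, so this position is not silent. Beside that, the step of a 1.5-fold higher number from compound 2 to compound 4 (0.16 log units; within the scatter) stays within the scatter, so the 2,4-dichlorophenyl and 2-fluorophenyl compounds cannot be ranked, and the step of a 1.5-fold lower number from compound 1 to compound 4 (0.17 log units; within the scatter) likewise leaves the diethylamino and (dimethylamino)methyl side chains unranked on this 2,4-dichlorophenyl ring. Nothing available explains why the number moves at this position.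

From the compounds shown here alone, it remains open whether a different group at this same carbon, such as methyl, methoxy or a carboxylic acid, would give a similar rise, a larger one or none. Going by these compounds, it is also open whether the new chloro would act alike on a ring without the 2-chloro, or on a ring carrying the 2-fluoro instead.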